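A few compounds are considered here, and "the series" means these few. Any claim that something is new, unique, unknown or untested is made for them only; others in the source may bear on it.

In a functional assay on MCF7 cells (Homo sapiens) for cytotoxicity, read by MTT assay, with a stated time of 48 h (on this read-out lower numbers stand for stronger inhibition and higher numbers for weaker inhibition), compound 1 `CCN(CC)C(=S)SC(CC(=O)c1ccccc1)c1ccccc1` gives 17000 nM and compound 2 `CCN(CC)C(=S)SC(CC(=O)c1ccccc1)c1ccc(Cl)cc1` gives 120 nM as its value. Compound 3 `CCN(CC)C(=S)SC(CC(=O)c1ccccc1)c1ccccc1OC` reads 16000 nM and so stands within the scatter of compound 1 but far from compound 2, with a 130-fold higher number from compound 2 to compound 3 (2.12 log units; beyond the scatter) as the large step between them. Next comes compound 4 `CCN(CC)C(=S)SC(CC(=O)c1ccccc1)c1ccccc1Cl` with the change chloro in place of methoxy on an aromatic carbon in which 2-chlorophenyl takes the place of 2-methoxyphenyl. For the measured compounds named here, two measured steps bear on it. Chloro in place of hydrogen gave a 140-fold lower number from compound 1 to compound 2 (2.15 log units; beyond the scatter) but as 4-chlorophenyl, and no 2-chlorophenyl compound has a value yet. Methoxy in place of hydrogen gave a 1.1-fold lower number from compound 1 to compound 3 (0.03 log units; within the scatter) and thus left compound 3 close to compound 1. A step to a lower number is therefore expected in this assay but smaller than the chloro step, and the uncertainty is wide. Compound 4 is estimated at 2000 nM within an expected range of 200 nM to 16000 nM for this compound. The expected step is an 8.0-fold lower number from compound 3 to compound 4 (0.90 log units; beyond the scatter) on this estimate.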

Compound 4, half-maximal inhibitory concentration: 4500 nM
Beside the measured number, compound 4's estimate is 2.3-fold (0.35 log units) below it, and the stated range covers the measured number.
By their numbers in this assay, from the lowest: compound 2; then compound 4; then compounds 3 and 1 (each within the scatter of the next).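

In this assay the place of the chloro matters more than its presence: 2-chlorophenyl gains only a modest step over the unsubstituted phenyl (a 3.8-fold lower number from compound 1 to compound 4 (0.58 log units; beyond the scatter)), and shifting the chloro away from 4-chlorophenyl costs most of the gain (a 38-fold higher number from compound 2 to compound 4 (1.57 log units; beyond the scatter)). This place also responds to the group it carries, as chloro in place of methoxy gives a modest but real step (a 3.6-fold lower number from compound 3 to compound 4 (0.55 log units; beyond the scatter)), although methoxy there stays within the scatter of hydrogen. Chloro at this place therefore falls short of 4-chlorophenyl, while still reading apart from both compound 1 and compound 3.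

Whether the large gain belongs to chloro alone stays open, since the compounds shown hold no bromo, nitrile or amine on this ring and methoxy appears only as 2-methoxyphenyl. No supporting measurement bears on why these steps differ in size.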